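Lengthening the Chain on the Core Nitrogen toward a Cyclohexyl

The compounds below may be only part of what the source reports. "The series", "measured", "known", "first", "only" and "open" are said of these compounds alone.

Measured compounds:
- compound 1, `CC(C)c1onc(-c2c(Cl)cccc2Cl)c1COc1ccc(-c2nc3cc(C(=O)O)ccc3n2C)cc1`: 4410 nM
- compound 2, `CCn1c(-c2ccc(OCc3c(-c4c(Cl)cccc4Cl)noc3C(C)C)cc2)nc2ccc(C(=O)O)cc21`: 5760 nM

Both compounds were tested in an assay on HEK-293T cells for antagonist activity at vitamin D3 receptor (Homo sapiens), read by a luciferase reporter, with a stated time of 24 h; a higher number here means a weaker inhibitor, a lower number a stronger inhibitor. Compound 1 gives 4410 nM and compound 2 gives 5760 nM in this assay; the two numbers lie within the usual scatter of repeated measurements, so the data do not separate them, and neither can be called the weaker or the stronger of the pair. Going by the values given here, compound 2 therefore stands at the same level as its only neighbour.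

The new compound 3, `CC(C)c1onc(-c2c(Cl)cccc2Cl)c1COc1ccc(-c2nc3ccc(C(=O)O)cc3n2CC2CCCCC2)cc1`, differs from compound 2 in one place: cyclohexyl in place of methyl on a saturated chain carbon bound to an aromatic nitrogen. Among the compounds with values here, no pair of measured compounds shows what such a change does to the number in this assay, so the direction of the step is open. The two measured values suggest that this part of the molecule can be varied with little visible effect, so the step from compound 2 to compound 3 is expected to be small, a 1.3-fold lower number from compound 2 to compound 3 (0.11 log units; within the scatter), and may well lie within the scatter. Compound 3 is expected to give 4500 nM in this assay, with a range from 1200 nM to 16000 nM.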

Compound 3, half-maximal inhibitory concentration: 346 nM
The estimate for compound 3 lay 13-fold (1.11 log units) above the measured number; the measured number lies below the stated range.
By their numbers in this assay, from the lowest: compound 3; then compounds 1 and 2 (each within the scatter of the next).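

In this assay, the group on a saturated chain carbon bound to an aromatic nitrogen proves to matter a great deal: cyclohexyl in place of methyl gives a 17-fold lower number from compound 2 to compound 3 (1.22 log units; beyond the scatter) and so a clearly stronger inhibitor. Read one bond further out, this is the change from ethyl to cyclohexylmethyl, which adds a six-membered non-aromatic ring of carbon only and no hydrogen-bond donors or acceptors, so this position tolerates a much larger all-carbon group and responds to it strongly, something the earlier pair of compounds, with no step between them, could not reveal. Nothing measured here explains why the number falls so far.

The compounds shown leave open whether the ring itself counts or simply the added carbon, a question that a straight hexyl chain or a phenyl ring on the same chain carbon would help to settle. They also leave open whether a ring containing nitrogen, such as piperidine, could stand in place of the cyclohexyl and keep the low number.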